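This account rests on a few compounds, and the source may have more. Where it says the series, first, only, none or still open, it means among the compounds named here.

Measured compounds:
- compound 1 `CCCCOc1ccc2[nH]c(-c3ccccc3)c(C3=C(Br)C(=O)NC3=O)c2c1`: 3.42
- compound 2 `CCCCCOc1ccc2[nH]c(-c3ccccc3)c(C3=C(Br)C(=O)NC3=O)c2c1`: 3.75
- compound 3 `CCCCOc1ccc2[nH]c(-c3ccc(OC)cc3)c(C3=C(Br)C(=O)NC3=O)c2c1`: 3.43

All three values come from a physicochemical assay for lipophilicity; on this read-out lower numbers stand for lower lipophilicity and higher numbers for higher lipophilicity. The change methyl in place of hydrogen on a saturated chain carbon, four bonds along the chain from an oxygen on an aromatic ring gave a number 0.33 log units higher from compound 1 to compound 2 (beyond the scatter). The same change, (methyl in place of hydrogen on a saturated chain carbon, four bonds along the chain from an oxygen on an aromatic ring), separates compound 3 from the unmeasured compound 4 `CCCCCOc1ccc2[nH]c(-c3ccc(OC)cc3)c(C3=C(Br)C(=O)NC3=O)c2c1`; the place is described in the same words in both cases. The cores of compound 1 and compound 3 differ by methoxy in place of hydrogen on an aromatic carbon, which gave a number 0.01 log units higher from compound 1 to compound 3 (within the scatter), so the two starting points stand close together in this assay.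

For compound 4 a step of about a number 0.33 log units higher from compound 3 to compound 4 (beyond the scatter) in this assay is expected, beside the earlier one, because the pair compound 1 and compound 2 showed a number 0.33 log units higher from compound 1 to compound 2 (beyond the scatter) for the same change. On that basis compound 4 is estimated at 3.76, within 3.55 to 3.97.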

Compound 4, partition coefficient: 3.77
Estimate against measurement, compound 4: 0.01 log units below; low and high end bracket the measured number.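

In this assay the methyl in place of hydrogen on a saturated chain carbon gave a number 0.34 log units higher from compound 3 to compound 4 (beyond the scatter), close to a number 0.33 log units higher from compound 1 to compound 2 (beyond the scatter), and the methoxy in place of hydrogen on an aromatic carbon gave a number 0.02 log units higher from compound 2 to compound 4 (within the scatter), so the two changes combined in compound 4 without any visible interaction. This holds for one pair of cores and one chain position only, and it does not show that the step carries to other cores or other chain lengths. No evidence on the reason for this agreement is available.

From the compounds shown here alone, whether the step holds on a longer chain, or with an amine or a carboxylic acid at the chain end, remains open. Also open, going by these compounds, is whether a core with a group other than methoxy behaves the same way.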